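Swapping a Chlorophenyl for a Difluorophenyl in a Kinase Inhibitor

A few compounds are considered here, and "the series" means these few. Any claim that something is new, unique, unknown or untested is made for them only; others in the source may bear on it.

Compound 1, `Cc1cc(Nc2nc(NCc3ccc(Cl)cc3)nc3ccccc23)n[nH]1`, is the weakest of the three measured compounds in an assay for inhibition of high affinity nerve growth factor receptor (Homo sapiens), read by HTRF, with a stated time of 30 min, in the presence of a further agent that is not named here (a lower number here means a stronger inhibitor, a higher number a weaker inhibitor), where compound 1 gives 380 nM. Its nearest neighbour is compound 2, `Cc1cc(Nc2nc(NCc3ccc(Br)cc3)nc3ccccc23)n[nH]1`, which in this assay gives 180 nM, a change described by a 2.1-fold lower number from compound 1 to compound 2 (0.32 log units; beyond the scatter). Far stronger is compound 3, `Cc1cc(Nc2nc(NCc3cc(F)ccc3F)nc3ccccc23)n[nH]1`, which in this assay gives 7.5 nM; the step of a 51-fold lower number from compound 1 to compound 3 (1.70 log units; beyond the scatter) is large, as is a 24-fold lower number from compound 2 to compound 3 (1.38 log units; beyond the scatter).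

The unmeasured compound 4, `Cc1cc(Nc2nc(NCc3ccc(F)c(F)c3)nc3ccccc23)n[nH]1`, differs from compound 1 by 3,4-difluorophenyl in place of 4-chlorophenyl on a saturated chain carbon bound to a nitrogen on an aromatic ring. The step that bears most directly on this is a 51-fold lower number from compound 1 to compound 3 (1.70 log units; beyond the scatter), since it too replaces 4-chlorophenyl with a difluorophenyl, though with the fluorines placed as 2,5-difluorophenyl rather than 3,4-difluorophenyl. A drop in the number is therefore expected, but with a different fluorine pattern its size is uncertain, so a step of an 8.4-fold lower number from compound 1 to compound 4 (0.93 log units; beyond the scatter) is estimated, smaller than that seen for compound 3. Compound 4 is thus expected to give 45 nM in this assay, within a range from 8 nM to 250 nM.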

Compound 4, half-maximal inhibitory concentration: 74 nM
Compound 4: middle estimate off by 1.6-fold (0.22 log units), on the low side, within the range that was stated.
By their numbers in this assay, from the lowest: compound 3; then compound 4; then compound 2; then compound 1.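

In this assay, the two difluorophenyl groups are not interchangeable: replacing 2,5-difluorophenyl with 3,4-difluorophenyl gives a 9.9-fold higher number from compound 3 to compound 4 (0.99 log units; beyond the scatter) on the same core. The large gain seen with compound 3 therefore depends on where the fluorines sit, not simply on there being two of them. Even so, 3,4-difluorophenyl still beats both single-halogen groups, with a 5.1-fold lower number from compound 1 to compound 4 (0.71 log units; beyond the scatter) for 4-chlorophenyl and a 2.4-fold lower number from compound 2 to compound 4 (0.39 log units; beyond the scatter) for 4-bromophenyl, so the ranking at this place is not set by the 2,5-difluorophenyl group alone.

No measurement shown here offers a reason for these differences. Still open, as far as these compounds go, is how a phenyl ring carrying a single fluorine, a methoxy group or a nitrile would compare, and what a longer chain would do at this place.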